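Propyl in Place of Chloro on an Aromatic Carbon

The compounds below may be only part of what the source reports. "The series", "measured", "known", "first", "only" and "open" are said of these compounds alone.

Among the compounds with values here, in an assay on membranes from brain for displacement of a labelled ligand from Neuronal acetylcholine receptor; alpha4/beta2 (Rattus norvegicus) (on this read-out lower numbers stand for stronger inhibition and higher numbers for weaker inhibition), compound 2 `CN1CCC[C@H]1COc1cncc(Cl)c1` gives 0.6 nM, the lower of the two numbers measured so far. Compound 1 `CCN(CC)C(=O)c1ccncc1OC[C@@H]1CCCN1C` gives 2830 nM in this assay, a far higher number, beyond the scatter. Compound 3 `CCCc1cncc(OC[C@@H]2CCCN2C)c1` differs from compound 2 by propyl in place of chloro on an aromatic carbon. Within the data shown here, no comparable step between measured compounds exists, so the expectation rests on compound 2 alone. A moderate move toward a higher number is expected, with the step of a 25-fold higher number from compound 2 to compound 3 (1.40 log units; beyond the scatter) lying beyond the scatter. Compound 3 is therefore estimated at 15 nM, with a range from 3 nM to 80 nM.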

Compound 3, inhibition constant: 0.12 nM
Compound 3: middle estimate off by 130-fold (2.10 log units), on the high side; measured number below the stated range.
By their numbers in this assay, from the lowest: compound 3; then compound 2; then compound 1.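

In this assay, the aromatic carbon two atoms from the ring nitrogen accepts propyl in place of chloro, and the change gives a 5.0-fold lower number from compound 2 to compound 3 (0.70 log units; beyond the scatter). A chain of three carbon atoms therefore keeps the number low at this position, and the step goes down rather than up. Within the data shown here, this is the first step at this position, since compound 1 differs from compound 2 in more than one place.

On these data alone, whether a longer chain such as butyl, or an amine or a carboxylic acid, would keep the number this low on the same carbon remains open. Nothing given here explains the direction of the step.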